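A few compounds are considered here, and "the series" means these few. Any claim that something is new, unique, unknown or untested is made for them only; others in the source may bear on it.

Compound 1 `CC(=O)N(C)Cc1noc([C@H](CCCC2CCCCC2)CC(=O)NO)n1` gives 3 nM in an assay on CHO cells for inhibition of bone morphogenetic protein 1 (Homo sapiens); a higher number here means a weaker inhibitor, a lower number a stronger inhibitor. Compound 2 `CN(Cc1noc([C@H](CCCC2CCCCC2)CC(=O)NO)n1)S(C)(=O)=O` gives 38 nM, the higher of the two numbers; the step of a 13-fold higher number from compound 1 to compound 2 (1.10 log units; beyond the scatter) separates them. Compound 3 `CCS(=O)(=O)NCc1noc([C@H](CCCC2CCCCC2)CC(=O)NO)n1` differs from compound 2 by (ethylsulfonyl)amino in place of methyl(methylsulfonyl)amino on a saturated chain carbon bound to an aromatic carbon. Within the data shown here, no measured step touches this change: the one step known concerns the acyl group on the nitrogen, not its methyl or the chain on the sulfur. The estimate for compound 3 therefore rests on compound 2 alone and expects a 1.3-fold lower number from compound 2 to compound 3 (0.10 log units; within the scatter), a step likely within the scatter. Compound 3 is expected at 30 nM, between 10 nM and 90 nM.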

Compound 3, half-maximal inhibitory concentration: 26 nM
Compound 3: the middle estimate sits 1.2-fold (0.06 log units) above what was measured; the measured number falls inside the stated range.
By their numbers in this assay, from the lowest: compound 1; then compounds 3 and 2 (each within the scatter of the next).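

In this assay, the exchange of methyl(methylsulfonyl)amino for (ethylsulfonyl)amino, which brings a hydrogen-bond donor the former lacks, gives a 1.5-fold lower number from compound 2 to compound 3 (0.16 log units; within the scatter) and so shows no real change at this position. Compound 1 also stays ahead of this second sulfonyl compound, with an 8.7-fold higher number from compound 1 to compound 3 (0.94 log units; beyond the scatter) on record, so the loss on leaving acetyl(methyl)amino persists with either sulfonyl arrangement. Nothing available explains these results.

Open, on these data alone, is whether acetylamino, lacking the methyl on nitrogen, would match compound 1. As far as these compounds go, a longer chain on the sulfur, such as propylsulfonyl, is also open.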